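Benzyl for cyclohexyl on the ring nitrogen: compound 4

This account rests on a few compounds, and the source may have more. Where it says the series, first, only, none or still open, it means among the compounds named here.

Measured in a functional assay on OVCAR-4 cells (Homo sapiens) for inhibition, read by sulforhodamine B assay, with a stated time of 48 h, tested at 10 uM; on this read-out lower numbers stand for less inhibition and higher numbers for more inhibition at the one concentration tested (going by the name of the read-out):
compound 1 `c1ccc(-c2cn3ccnc3c(-c3ccc4ncn(C5CCCCC5)c4c3)n2)cc1` gives 34.5%
compound 2 `O=Cc1ccc(-c2cn3ccnc3c(-c3ccc4ncn(C5CCCCC5)c4c3)n2)cc1` gives 16.9%
compound 3 `Fc1ccccc1-c1cn2ccnc2c(-c2ccc3ncn(C4CCCCC4)c3c2)n1` gives 4.51%

Compound 2 stands second highest of the three in this assay, with the change a number 17.6 percentage points lower from compound 1 to compound 2 (beyond the scatter) above it and a number 12.4 percentage points lower from compound 2 to compound 3 (beyond the scatter) below it; the third step, a number 30 percentage points lower from compound 1 to compound 3 (beyond the scatter), also lies beyond the scatter. Compound 4 `O=Cc1ccc(-c2cn3ccnc3c(-c3ccc4ncn(Cc5ccccc5)c4c3)n2)cc1` differs from compound 2 by benzyl in place of cyclohexyl on an aromatic nitrogen. None of the three measured steps touches this place: all of them alter the group on the aromatic carbon of the phenyl, while the cyclohexyl is kept throughout. Among the measured compounds shown here, no measured step therefore bears on the move to compound 4, and no direction can be read from the series. For compound 4 the expected step is a number 0.1 percentage points higher from compound 2 to compound 4 (within the scatter), which is within the scatter of no change. The estimate for compound 4 in this assay is 17%, with a range from 0% to 45%, wide for want of any precedent.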

Compound 4, a percentage reported as inhibition, at one concentration (the size of the read-out at that concentration, not a potency): 16.9%
Estimate against measurement, compound 4: 0.1 percentage points above, and the stated range covers the measured number.
By their numbers in this assay, from the lowest: compound 3; then compounds 2 and 4 (each within the scatter of the next); then compound 1.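

In this assay, among the compounds shown here, the first change at the ring nitrogen reads no change at the digits printed from compound 2 to compound 4 (within the scatter) when benzyl replaces cyclohexyl, with the 4-formylphenyl group held constant. With that group in place, this read-out does not separate the aromatic ring of benzyl from the non-aromatic ring of cyclohexyl. No measured evidence bears on this result.

Open, going by these compounds, is whether benzyl gives the same outcome with the phenyl of compound 1 or the 2-fluorophenyl of compound 3. Also open, on these data alone, is whether an amine or a carboxylic acid on a longer chain at this nitrogen would shift the number.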